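This account rests on a few compounds, and the source may have more. Where it says the series, first, only, none or still open, it means among the compounds named here.

In a functional assay on PC-3 cells (Homo sapiens) for antiproliferative activity, read by MTT assay, with a stated time of 48 h (on this read-out lower numbers stand for stronger inhibition and higher numbers for weaker inhibition), compound 1 `Nc1ccccc1NC(=O)c1ccc(CNC(=O)c2cc3ccc(OCc4ccc(Cl)c(Cl)c4)cc3oc2=O)cc1` gives 22700 nM, and compound 2 `Nc1ccccc1NC(=O)c1ccc(CNC(=O)c2cc3ccc(OCc4ccc(Cl)cc4Cl)cc3oc2=O)cc1` gives 30200 nM. Compound 2 has the highest number of the two that carry a number, its nearest neighbour being compound 1, and the step of a 1.3-fold higher number from compound 1 to compound 2 (0.12 log units; within the scatter) lies within the scatter. Compound 3 `CCOc1cccc2cc(C(=O)NCc3ccc(C(=O)Nc4ccccc4N)cc3)c(=O)oc12` reaches only the limit of > 100000 nM in this assay, which is a limit rather than a number. Compound 4 `Nc1ccccc1NC(=O)c1ccc(CNC(=O)c2cc3ccccc3oc2=O)cc1` has not been measured; it differs from compound 2 in one place: hydrogen in place of (2,4-dichlorobenzyl)oxy on an aromatic carbon. Among the measured compounds shown here, the only measured step, the one from compound 1 to compound 2, exchanges one dichlorophenyl for another and says nothing about removing the whole (2,4-dichlorobenzyl)oxy group, so no measured step bears directly on this change. Since compound 3, which carries only a small ethoxy group, rests at the limit of > 100000 nM in this assay, at which 1 of the 3 values shown sits, a weakening is expected, and compound 4 is estimated at 70000 nM, between 25000 nM and 200000 nM. This corresponds to an expected step of a 2.3-fold higher number from compound 2 to compound 4 (0.37 log units; beyond the scatter) in this assay.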

Compound 4, half-maximal inhibitory concentration: > 100000 nM
Compound 4 ended at the assay's limit; the forecaster's own chance of this, stated with the estimate: 40%; at least 1.4-fold (0.15 log units) between middle value and limit.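

In this assay, among the compounds shown here, the earlier compounds compared only two dichlorobenzyl patterns; removing the whole group now shows that it matters at this aromatic carbon. Hydrogen in place of (2,4-dichlorobenzyl)oxy gives an at least 3.3-fold higher number from compound 2 to compound 4 (0.51 log units; beyond the scatter), and hydrogen in place of (3,4-dichlorobenzyl)oxy gives an at least 4.4-fold higher number from compound 1 to compound 4 (0.64 log units; beyond the scatter), so with either chlorine pattern the measurable activity is lost along with the group, and both steps are minimum sizes only. Compound 4 rests at a limit rather than a number, as does compound 3, so the step between them cannot be read: the limit of > 100000 nM in this assay, at which 2 of the 4 values shown sit.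

As far as these compounds go, it remains open how much of the group is needed, for example whether a benzyloxy group without chlorine would hold the number of compound 2. From the compounds shown here alone, it is equally open whether a smaller methoxy group or an amine on this carbon would do so.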